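Swapping a thiophene for a pyridine on a urea core

A few compounds are considered here, and "the series" means these few. Any claim that something is new, unique, unknown or untested is made for them only; others in the source may bear on it.

Measured so far in a functional assay on MDA-MB-231 cells (Homo sapiens) for cytotoxicity, read by MTT assay, with a stated time of 48 h; a lower number here means a stronger inhibitor, a higher number a weaker inhibitor:
Compound 1 `O=C(NCc1ccccc1)N(Cc1ccccn1)n1cnnc1` gives > 50000 nM, a limit of the assay.
Compound 2 `Cc1ccc(NC(=O)N(Cc2ccccn2)n2cnnc2)cc1` gives 39500 nM.
Compound 3 `Cc1ccsc1CN(C(=O)Nc1ccccc1)n1cnnc1` gives > 50000 nM, also a limit of the assay.

Compound 3 therefore stands at the edge of what this assay can report, sharing the limit of > 50000 nM in this assay, at which 2 of the 3 values shown sit, with compound 1, so its true value could be anywhere beyond that limit. The step to compound 4 `O=C(Nc1ccccc1)N(Cc1ccccn1)n1cnnc1` is pyridin-2-yl in place of 3-methylthiophen-2-yl on a saturated chain carbon bound to an amide-type nitrogen: the methyl group attached to the urea nitrogen is replaced by a pyridin-2-ylmethyl group, the same group that compounds 1 and 2 carry.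

Among the measured compounds shown here, no measured step covers this exact exchange. For the measured compounds named here, the only measured step, an at least 1.2-fold lower number from compound 1 to compound 2 (0.10 log units; that floor lies within the scatter), changes the other side of the urea and lies within the scatter, so it gives no guidance on the thiophene-to-pyridine swap. What the values do show is that compound 1, which already carries the pyridin-2-ylmethyl group, sits at the limit, and compound 2 gives a number only just inside the measurable range.

Given this, compound 4 is expected to stay near the limit: a number no higher from compound 3 to compound 4 (the limit leaves the size open) is estimated as no change beyond the scatter, with a good chance that only a limit is reported. The estimate for compound 4 is 50000 nM, within 20000 nM to 200000 nM.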

Compound 4, half-maximal inhibitory concentration: > 50000 nM
Compound 4 ended at the assay's limit (the forecaster's own chance of this, stated with the estimate: 65%); the middle value sits exactly at the limit.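

The exchange of 3-methylthiophen-2-yl for pyridin-2-yl on a saturated chain carbon bound to an amide-type nitrogen does not bring compound 4 into the measurable range, so neither ring gives a readable number here, and the steps to compound 4 from compound 3 and from compound 1 cannot be read, since both ends of each are limits. Among the compounds shown here, the one step that can be read, an at least 1.2-fold higher number from compound 2 to compound 4 (0.10 log units; that floor lies within the scatter), is hydrogen in place of methyl on an aromatic carbon, and it does not show that this methyl group matters. For the compounds shown here, only one compound now has a true number, and the others gather at a single end of the scale: the limit of > 50000 nM in this assay, at which 3 of the 4 values shown sit.

How far each of these compounds lies beyond the limit stays unknown, so the thiophene and the pyridine cannot be ranked against each other in this assay. On these data alone, it also remains open whether an amine or a carboxylic acid carried on a saturated chain carbon bound to an amide-type nitrogen, in place of either ring, would give a readable number.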